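Trimethoxyphenyl replacing hydroxyphenyl in a pyrazoline sulfonamide series

This account rests on a few compounds, and the source may have more. Where it says the series, first, only, none or still open, it means among the compounds named here.

Measured so far:
compound 1 `Cc1cc(O)c(C2=NN(c3ccc(S(N)(=O)=O)cc3)C(c3ccccc3O)C2)cc1Cl`: 1930 nM
compound 2 `COc1ccc(C2CC(c3cc(Cl)c(C)cc3O)=NN2c2ccc(S(N)(=O)=O)cc2)cc1OC`: 3920 nM

In a functional assay on HOP-62 cells (Homo sapiens) for antiproliferative activity, with a stated time of 48 h (on this read-out higher numbers stand for weaker inhibition of growth and lower numbers for stronger inhibition of growth), compound 1 gives the lowest number of the two shown; compound 2 sits at a 2.0-fold higher number from compound 1 to compound 2 (0.31 log units; beyond the scatter). Compound 3 `COc1ccc(C2CC(c3cc(Cl)c(C)cc3O)=NN2c2ccc(S(N)(=O)=O)cc2)c(OC)c1OC` differs from compound 1 by 2,3,4-trimethoxyphenyl in place of 2-hydroxyphenyl on a saturated ring carbon. Within the data shown here, only one measured step bears on this change, the one from compound 1 to compound 2, where a methoxy-bearing phenyl also replaced the 2-hydroxyphenyl and the number rose modestly. A step of similar size and direction is therefore expected here, estimated as a 2.1-fold higher number from compound 1 to compound 3 (0.32 log units; beyond the scatter). Compound 3 is expected to give 4000 nM, with a range from 1900 nM to 9000 nM.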

Compound 3, concentration for 50% growth inhibition: 2100 nM
Compound 3: the middle estimate sits 1.9-fold (0.28 log units) above what was measured, within the range that was stated.
By their numbers in this assay, from the lowest: compounds 1, 3 and 2 (each within the scatter of the next, the first and the last beyond it).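

In this assay, 2,3,4-trimethoxyphenyl in place of 2-hydroxyphenyl on the saturated ring carbon gives a 1.1-fold higher number from compound 1 to compound 3 (0.04 log units; within the scatter), so this position accepts a larger group with 0 hydrogen-bond donors without a change that stands out from the scatter. Methoxy in place of hydrogen on an aromatic carbon gives a 1.9-fold lower number from compound 2 to compound 3 (0.27 log units; within the scatter), so this added methoxy shows no clear effect either. No measurement is available to explain these results. Still open, from the compounds shown here alone, is whether an amine or a carboxylic acid on this phenyl ring would move the number beyond the scatter.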